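The source may hold more compounds than are shown below. What is called first, only, known or untested is meant among the compounds shown, and "the series" means these compounds.

Compound 3 `Cc1cccc(NC(=O)CN2CCC(c3cccc(C#N)n3)CC2)c1` stands second highest of the three numbers in a functional assay on HEK293 cells for agonist activity at D(4) dopamine receptor (Homo sapiens), read by FLIPR (a lower number here means that less compound is needed, a higher number that more compound is needed for the effect), at 36 nM. Its nearest neighbour is compound 1 `O=C(CN1CCC(c2cccc[n+]2[O-])CC1)Nc1cccc(Cl)c1`, which in this assay gives 62 nM, within the scatter of compound 3; compound 2 `Cc1cccc(NC(=O)CN2CCC(c3cccc(O)c3)CC2)c1` gives 8 nM and lies beyond the scatter below compound 3. Compound 4 `Cc1cccc(NC(=O)CN2CCC(c3ccccc3C)CC2)c1` carries 2-methylphenyl in place of 6-cyanopyridin-2-yl on a saturated ring carbon. Within the data shown here, the one step that bears on this change is a 4.5-fold higher number from compound 2 to compound 3 (0.65 log units; beyond the scatter), where an aromatic ring of carbon only gave way to a ring with one hetero atom. Returning to a carbon-only ring is therefore expected to give a modest step toward a lower number, a 1.8-fold lower number from compound 3 to compound 4 (0.26 log units; within the scatter), though compound 4 lacks the 3-hydroxyphenyl of compound 2. Compound 4 is accordingly estimated at 20 nM, within 6 nM to 65 nM.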

Compound 4, half-maximal effective concentration: 340 nM
Estimate against measurement, compound 4: 17-fold (1.23 log units) below; measured number above the stated range.
By their numbers in this assay, from the lowest: compound 2; then compounds 3 and 1 (each within the scatter of the next); then compound 4.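

In this assay, the change to 2-methylphenyl gives a 9.4-fold higher number from compound 3 to compound 4 (0.98 log units; beyond the scatter), so a carbon-only aromatic ring at this saturated ring carbon does not by itself give a lower number. The change from 3-hydroxyphenyl gives a 43-fold higher number from compound 2 to compound 4 (1.63 log units; beyond the scatter), placing the two carbon-only rings on either side of the 6-cyanopyridin-2-yl of compound 3. Nothing measured here explains these differences. The compounds shown do not separate the effect of the substituent from that of its ring position, and an unsubstituted phenyl or 3-methylphenyl at this carbon would bear on that.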